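Weak MCF7 antiproliferatives: triazole aryl swaps at the limit

This account rests on a few compounds, and the source may have more. Where it says the series, first, only, none or still open, it means among the compounds named here.

Compound 1 `CCOc1ccc(-n2nncc2CN2C(=O)C3(C(C#N)=C(N)Oc4c(N)cc5nc6ccccc6nc5c43)c3ccccc32)cc1`: 26800 nM
Compound 2 `Cc1cc(C)cc(-n2nncc2CN2C(=O)C3(C(C#N)=C(N)Oc4c(N)cc5nc6ccccc6nc5c43)c3ccccc32)c1`: > 50000 nM

In a functional assay on MCF7 cells (Homo sapiens) for antiproliferative activity, read by MTT assay, with a stated time of 48 h (a higher number here means a weaker inhibitor, a lower number a stronger inhibitor), compound 1 gives 26800 nM. In this assay compound 2 gives only the limit > 50000 nM. Among the compounds with values here, the one measured step, an at least 1.8-fold higher number from compound 1 to compound 2 (0.27 log units; that floor lies within the scatter), rests on (the limit of > 50000 nM in this assay, at which 1 of the 2 values shown sits), so its true size is unknown. Compound 3 `N#CC1=C(N)Oc2c(N)cc3nc4ccccc4nc3c2C12C(=O)N(Cc1cnnn1-c1cc(Cl)ccc1Cl)c1ccccc12` differs from compound 2 by 2,5-dichlorophenyl in place of 3,5-dimethylphenyl on an aromatic nitrogen. Within the data shown here, both measured values sit near the weak end, and the only step is a limit, so no change beyond the scatter is expected. The expected step of an at least 1.1-fold lower number from compound 2 to compound 3 (0.04 log units; that floor lies within the scatter) reflects this. Compound 3 is estimated at 45000 nM, within 15000 nM to 100000 nM.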

Compound 3, half-maximal inhibitory concentration: 33200 nM
Estimate against measurement, compound 3: 1.4-fold (0.13 log units) above; low and high end bracket the measured number.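

With the 2,5-dichlorophenyl group on the aromatic nitrogen, compound 3 gives a measured number, whereas compound 2 has only a limit. On these data alone, the step reads an at least 1.5-fold lower number from compound 2 to compound 3 (0.17 log units; that floor lies within the scatter) and its true size stays unknown: the limit of > 50000 nM in this assay, at which 1 of the 3 values shown sits. Replacing 4-ethoxyphenyl with 2,5-dichlorophenyl gives a 1.2-fold higher number from compound 1 to compound 3 (0.09 log units; within the scatter) and so does not separate these two groups.

As far as these compounds go, whether a phenyl ring bearing an amine or a carboxylic acid at this position would move the number out of this weak range stays open. So does the effect of replacing the phenyl ring with a plain methyl group.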